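Filling the amide hydrogen in a weak orexin antagonist

This account rests on a few compounds, and the source may have more. Where it says the series, first, only, none or still open, it means among the compounds named here.

Of the compounds shown here, three sharing one core have been measured for antagonism at the orexin type 2 receptor. In a functional assay on cells for antagonist activity at Orexin receptor type 2 (Homo sapiens), read by fluorescence and calcium flux, with a stated time of 30 min (a lower number here means a stronger inhibitor, a higher number a weaker inhibitor), compound 1 `CCN(C(=O)c1cc(C)ccc1-n1nccn1)[C@@H](C)Cn1ccc(-c2ccc(F)cn2)n1` gives 1.61 nM, compound 2 `Cc1ccc(-n2nccn2)c(C(=O)N(C)CCn2ccc(-c3ccc(F)cn3)n2)c1` gives 11.9 nM, and compound 3 `Cc1ccc(-n2nccn2)c(C(=O)N[C@@H](C)Cn2cc(-c3ccc(F)cn3)cn2)c1` gives 840 nM. Compound 3 therefore stands highest of the three numbers: its nearest neighbour, compound 2, lies far lower, beyond the scatter, and compound 1 lies further still.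

Compound 4 `CCN(C(=O)c1cc(C)ccc1-n1nccn1)[C@@H](C)Cn1cc(-c2ccc(F)cn2)cn1` follows from compound 3 by one change, (ethyl in place of hydrogen on an amide-type nitrogen). Among the compounds with values here, no measured pair shows exactly this step, so its size is not known. Within the data shown here, what the values do show is that compound 1, which likewise carries an ethyl group on an amide-type nitrogen, gives 1.61 nM, a very low number, while the only compound with a free amide hydrogen, compound 3, gives 840 nM. On that basis a large fall in this assay is expected, with the step of a 34-fold lower number from compound 3 to compound 4 (1.53 log units; beyond the scatter) lying well beyond the scatter. Compound 4 is estimated at 25 nM, in a range from 5 nM to 150 nM.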

Compound 4, half-maximal inhibitory concentration: 5.87 nM
The estimate for compound 4 lay 4.3-fold (0.63 log units) above the measured number, within the range that was stated.
By their numbers in this assay, from the lowest: compound 1; then compound 4; then compound 2; then compound 3.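

Putting ethyl in place of hydrogen on the amide-type nitrogen gives a 140-fold lower number from compound 3 to compound 4 (2.16 log units; beyond the scatter) in this assay. The earlier compounds shown here could only hint at the importance of this position, since compound 3 differed from each of them in more than one place; this pair isolates the change, and the addition of just two carbon atoms moves the number by a large amount. Nothing available explains the size of this step.

The compounds shown leave open whether the step is specific to ethyl, since neither methyl nor a longer chain such as propyl appears on this nitrogen with the rest of compound 4 held constant. They also leave open whether a ring such as cyclopropyl, or a chain ending in an amine, would be accepted at this position.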